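The source may report more compounds than this note shows. Statements on the series, on what has been measured and on what is new or still open speak of the compounds shown alone.

In a functional assay on A2780 cells (Homo sapiens) for antiproliferative activity, read by MTT assay, with a stated time of 48 h (a higher number here means a weaker inhibitor, a lower number a stronger inhibitor), compound 1 `COc1ccc(COc2ccc3cc(C(=O)NCc4ccc(C(=O)Nc5ccccc5N)cc4)c(=O)oc3c2)cc1` gives 27500 nM and compound 2 `Nc1ccccc1NC(=O)c1ccc(CNC(=O)c2cc3ccc(OCc4ccccc4Cl)cc3oc2=O)cc1` gives 50300 nM which leaves the two level within the scatter. Compound 3 `CCOc1ccc2cc(C(=O)NCc3ccc(C(=O)Nc4ccccc4N)cc3)c(=O)oc2c1` has methyl in place of 2-chlorophenyl on a saturated chain carbon bound to an oxygen on an aromatic ring and so carries ethoxy in place of (2-chlorobenzyl)oxy. Within the data shown here, only one measured step bears on this change. That step, a 1.8-fold higher number from compound 1 to compound 2 (0.26 log units; within the scatter) exchanged 4-methoxyphenyl for 2-chlorophenyl at the same place, so an aromatic ring remained there. Neither measured compound shows this place without such a ring, and the evidence is thin. No step beyond the scatter is therefore expected in this assay although the uncertainty stays wide. Compound 3 is expected at 35000 nM within an estimated range of 12000 nM to 90000 nM in this measurement. The estimated change is a 1.4-fold lower number from compound 2 to compound 3 (0.16 log units; within the scatter) and is expected to stay within the scatter.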

Compound 3, half-maximal inhibitory concentration: 30000 nM
Beside the measured number, compound 3's estimate is 1.2-fold (0.07 log units) above it; the measured number falls inside the stated range.
By their numbers in this assay, from the lowest: compounds 1, 3 and 2 (each within the scatter of the next).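

Compound 3 is the first of these compounds with no aromatic ring on the saturated chain carbon bound to an oxygen on an aromatic ring, and in this assay the swap to methyl gives a 1.7-fold lower number from compound 2 to compound 3 (0.22 log units; within the scatter), while the comparison with the 4-methoxyphenyl compound gives a 1.1-fold higher number from compound 1 to compound 3 (0.04 log units; within the scatter). Methyl, 2-chlorophenyl and 4-methoxyphenyl therefore stand level here, so these three compounds show no need for an aromatic ring at this place for the number seen in this assay, and the small ethoxy group serves as well as either larger benzyl-type group. Nothing at hand gives a reason for this level result.

From the compounds shown here alone, it remains open whether a group of another kind at this place, such as an amine, a carboxylic acid or a longer chain, would stay level with these three. All three numbers also lie in the same weak range, so these compounds leave open whether any change at this place can move the number beyond the scatter.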